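Chain swap on the aromatic nitrogen: compound 3 to compound 4

A few compounds are considered here, and "the series" means these few. Any claim that something is new, unique, unknown or untested is made for them only; others in the source may bear on it.

Measured so far in an in vitro ADME assay on microsomes from liver (Homo sapiens) for metabolic stability, tested at 5 uM; a lower number here means that the compound disappears faster, a higher number that the compound lasts longer:
- compound 1, `CS(=O)(=O)Nc1ccc2c(c1)S(=O)(=O)N=C(c1c(O)c(-c3ccsc3)nn(CCC3CC3)c1=O)N2`: compound 1 gives 0.517 h
- compound 2, `CC(C)CCn1nc(C2CCCC2)c(O)c(C2=NS(=O)(=O)c3cc(NS(C)(=O)=O)ccc3N2)c1=O`: compound 2 gives 0.283 h
- compound 3, `CCCC(C)n1nc(-c2cccs2)c(O)c(C2=NS(=O)(=O)c3cc(NS(C)(=O)=O)ccc3N2)c1=O`: compound 3 gives > 1 h, which is a limit of the assay and not a number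

Compound 3 therefore sits at the top of the range covered here, as noted in the limit of > 1 h in this assay, at which 1 of the 3 values shown sits. Among the compounds with values here, compound 1 and compound 2 both give numbers below that limit, and no single-point step between any two of the measured compounds is available, so what the chain on the aromatic nitrogen does cannot be read off directly.

Compound 4, `CS(=O)(=O)Nc1ccc2c(c1)S(=O)(=O)N=C(c1c(O)c(-c3cccs3)nn(CCC3CCCCC3)c1=O)N2`, differs from compound 3 in one place: 2-cyclohexylethyl in place of 1-methylbutyl on an aromatic nitrogen. With only a limit for compound 3, the step of an at least 1.4-fold lower number from compound 3 to compound 4 (0.15 log units; that floor lies within the scatter) that is expected here is a guess at a modest drop below the limit, since the two measured compounds with a number, compound 1 and compound 2, lie below it. Compound 4 is expected to give about 0.7 h, somewhere between 0.3 h and 1.5 h, with a fair chance that this assay again reports only a limit.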

Compound 4, half-life: > 1 h
Compound 4: no number, only a limit; the forecaster's own chance of this, stated with the estimate: 35%; middle value at least 1.4-fold (0.15 log units) from the limit.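

In this assay compound 3 and compound 4 both give only a limit, so no step can be read between them. The compounds shown leave open how long either compound lasts and whether 2-cyclohexylethyl in place of 1-methylbutyl changes the half-life at all.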